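The compounds below may be only part of what the source reports. "The series", "measured", "known", "first", "only" and "open" are said of these compounds alone.

Measured compounds:
compound 1, `COc1cc(C)cc(-c2c(-c3ccnc(-c4ccc(C(C)=O)cc4)c3)cnn2CC#N)c1`, 3120 nM
compound 2, `Cc1cc(O)cc(-c2nn(CC#N)cc2-c2ccnc(-c3ccc(Oc4ccccc4)cc3)c2)c1`, 2660 nM
compound 3, `COc1cc(C)cc(-c2nn(CC#N)cc2-c2ccnc(-c3ccc(N(C)C)cc3)c2)c1`, 1620 nM

In a functional assay on BT-549 cells (Homo sapiens) for inhibition, read by sulforhodamine B assay, with a stated time of 48 h (on this read-out higher numbers stand for weaker inhibition of growth and lower numbers for stronger inhibition of growth), compound 1 gives 3120 nM, the highest of the three numbers. Its nearest neighbour is compound 2 at 2660 nM, and the furthest is compound 3 at 1620 nM; both gaps to compound 1 lie within the scatter, so the three compounds cannot be placed in an order of growth inhibition on these data.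

Compound 4, `COc1cc(C)cc(-c2c(-c3ccnc(-c4ccc(N(C)C)cc4)c3)cnn2CC#N)c1`, has not been measured. It differs from compound 1 in one place: dimethylamino in place of acetyl on an aromatic carbon. Within the data shown here, no step between measured compounds covers this exchange directly, so the expectation rests on what the set shows. Compound 3 carries a 4-(dimethylamino)phenyl group on a closely related core and gives 1620 nM, a number that sits within the scatter of compound 1.

The step from compound 1 to compound 4 is therefore expected to be small, a 1.6-fold lower number from compound 1 to compound 4 (0.22 log units; within the scatter), and not clearly beyond the scatter. For compound 4 the estimate in this assay is 1900 nM, with a range from 700 nM to 5000 nM.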

Compound 4, concentration for 50% growth inhibition: 75.1 nM
Compound 4: the middle estimate sits 25-fold (1.40 log units) above what was measured; measured number outside the range, below it.
By their numbers in this assay, from the lowest: compound 4; then compounds 3, 2 and 1 (each within the scatter of the next).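

In this assay, among these compounds, exchanging 4-acetylphenyl for 4-(dimethylamino)phenyl gives a 42-fold lower number from compound 1 to compound 4 (1.62 log units; beyond the scatter), the only step here that stands clear of the scatter. Among the compounds shown here, it shows that this position, on an aromatic carbon para to a large group, is not indifferent to what it carries: two groups with the same count of heavy atoms, donors and acceptors are far apart in growth inhibition, which the earlier compounds, all within the scatter of one another, gave no sign of. Nothing among the data shown explains this difference. From the compounds shown here alone, it remains open whether a primary amine, a monomethylamino group or a morpholine at this position would give a number like that of compound 4, or whether both methyl groups on the nitrogen are needed. A methoxy group in the same place would show whether a nitrogen is required at all.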